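A few compounds are considered here, and "the series" means these few. Any claim that something is new, unique, unknown or untested is made for them only; others in the source may bear on it.

Compound 1 `COC(=O)C1=C(C)N=C(C)/C(=C(\O)OC)C1c1ccccc1Cl` is the reference point of this series. Going by the values given here, in a functional assay (muscle tissue) with Cavia porcellus as the target (on this read-out lower numbers stand for an effect already at smaller amounts and higher numbers for an effect only at larger amounts of compound), compound 1 gives 2.19 nM, the lowest of the three numbers measured so far. Its nearest neighbour is compound 3 `COC(=O)C1=C(C)N=C(C)/C(=C(\O)OC)C1c1ccccc1Br`, which in this assay gives 7.59 nM; the step there is a 3.5-fold higher number from compound 1 to compound 3 (0.54 log units; beyond the scatter). Compound 2 `COC(=O)C1=C(C)N=C(C)/C(=C(\O)OC)C1c1ccccc1F` stands furthest away, giving 42.7 nM in this assay, a step of a 19-fold higher number from compound 1 to compound 2 (1.29 log units; beyond the scatter). Between those two the change is a 5.6-fold lower number from compound 2 to compound 3 (0.75 log units; beyond the scatter).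

Compound 4 `COC(=O)C1=C(C)N=C(C)/C(=C(\O)OC)C1c1ccccc1C` differs from compound 1 in one place: methyl in place of chloro on an aromatic carbon. Among the compounds with values here, no measured step swaps chloro for methyl, so the bearing of the earlier steps is indirect; they show only that replacing chloro by fluoro costs a large step and by bromo a modest one. The change to methyl is therefore expected to raise the number by a modest amount, a 2.7-fold higher number from compound 1 to compound 4 (0.44 log units; beyond the scatter). For compound 4 in this assay the estimate is 6 nM, with a range from 1.5 nM to 25 nM.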

Compound 4, half-maximal effective concentration: 6.03 nM
Compound 4: middle estimate off by 1.0-fold (0.00 log units), on the low side; the measured number falls inside the stated range.
By their numbers in this assay, from the lowest: compound 1; then compounds 4 and 3 (each within the scatter of the next); then compound 2.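

Going by these compounds alone, with 2-chlorophenyl changed to 2-methylphenyl, a group other than a halogen enters this place for the first time, and in this assay the change gives a 2.8-fold higher number from compound 1 to compound 4 (0.44 log units; beyond the scatter) while chloro keeps the lowest number of the four groups. Methyl and bromo are not told apart, with a 1.3-fold lower number from compound 3 to compound 4 (0.10 log units; within the scatter) lying within the scatter, whereas a 7.1-fold lower number from compound 2 to compound 4 (0.85 log units; beyond the scatter) leaves fluoro alone at the high end. No measurement given here bears on the cause of these steps.

The compounds shown leave open how methoxy, trifluoromethyl or an amine would stand at this place on the ring. They also leave open whether the same steps would hold with the ester groups of the shared core changed.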